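Swapping the Amino Group of Compound 1 for Benzyl(methyl)amino

The source may report more compounds than this note shows. Statements on the series, on what has been measured and on what is new or still open speak of the compounds shown alone.

In a functional assay on HeLa cells (Homo sapiens) for antiproliferative activity, read by cell counting, with a stated time of 2 days (a lower number here means a stronger inhibitor, a higher number a weaker inhibitor), compound 1 `COc1cc(C(=O)c2sc(N)nc2N)cc(OC)c1OC` gives 31000 nM, level with compound 3 `CCCCN(C)c1nc(N)c(C(=O)c2cc(OC)c(OC)c(OC)c2)s1` at 31000 nM, while compound 2 `CCN(CC)c1nc(N)c(C(=O)c2cc(OC)c(OC)c(OC)c2)s1` gives 38000 nM; all three lie within the scatter of one another. Compound 4 `COc1cc(C(=O)c2sc(N(C)Cc3ccccc3)nc2N)cc(OC)c1OC` differs from compound 1 in one place: benzyl(methyl)amino in place of amino on an aromatic carbon. Two measured swaps at that same place bear on it, a 1.2-fold higher number from compound 1 to compound 2 (0.09 log units; within the scatter) and no change at the digits printed from compound 1 to compound 3 (within the scatter), and neither goes beyond the scatter. Neither entering group has the six-membered aromatic ring that enters here, so this expectation remains uncertain. No change beyond the scatter is expected in this assay, with an estimated 1.2-fold lower number from compound 1 to compound 4 (0.09 log units; within the scatter). For compound 4, the expected value is 25000 nM, with an estimated range of 7000 nM to 60000 nM.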

Compound 4, half-maximal inhibitory concentration: > 200000 nM
Compound 4: no number, only a limit (the forecaster's own chance of this, stated with the estimate: 15%); middle value at least 8.0-fold (0.90 log units) from the limit.
By their numbers in this assay, from the lowest: compounds 1, 3 and 2 (each within the scatter of the next). At a limit, above all of these: compound 4.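

Compound 4 has no exact number in this assay, only a limit: the limit of > 200000 nM in this assay, at which 1 of the 4 values shown sits. This position is thus not indifferent to what it carries: diethylamino and butyl(methyl)amino stayed within the scatter of amino, whereas benzyl(methyl)amino brings an at least 6.4-fold higher number from compound 1 to compound 4 (0.80 log units; beyond the scatter) and an at least 5.2-fold higher number from compound 2 to compound 4 (0.72 log units; beyond the scatter). The closest pair shows that phenyl in place of propyl on the chain is enough for an at least 6.4-fold higher number from compound 3 to compound 4 (0.80 log units; beyond the scatter).

Going by these compounds, whether this rise needs an aromatic ring stays open, since cyclohexyl in place of phenyl would be needed to separate ring from aromatic ring.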